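A few compounds are considered here, and "the series" means these few. Any claim that something is new, unique, unknown or untested is made for them only; others in the source may bear on it.

Measured so far:
compound 1 `COC(=O)c1ccccc1-c1cnc(C(=O)CCCCCCc2ccccc2)o1`, 60 nM
compound 2 `O=C(CCCCCCc1ccccc1)c1ncc(-c2ccccc2F)o1`, 110 nM
compound 3 `COC(=O)c1cccc(-c2cnc(C(=O)CCCCCCc3ccccc3)o2)c1`, 12 nM

In an assay (Rattus norvegicus) for inhibition of Fatty-acid amide hydrolase 1 (Homo sapiens) (on this read-out higher numbers stand for weaker inhibition and lower numbers for stronger inhibition), compound 3 stands lowest of the three numbers. Compound 1 gives 60 nM and compound 2 gives 110 nM, and both gaps to compound 3 lie beyond the scatter, so compound 3 is the strongest inhibitor among the measured compounds.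

Compound 4 `O=C(CCCCCCc1ccccc1)c1ncc(-c2cccc(C(=O)C(F)(F)F)c2)o1` differs from compound 3 in one place: trifluoromethyl in place of methoxy on a carbonyl carbon. Among the compounds with values here, the only step measured, a 1.8-fold higher number from compound 1 to compound 2 (0.26 log units; within the scatter), concerns a different exchange on an aromatic carbon and stays within the scatter; no measured pair touches the carbonyl carbon or the groups attached to it. Within the data shown here, no step bears directly on the change from compound 3 to compound 4, so the expectation rests on compound 3 alone, which gives 12 nM in this assay.

In this assay the expected step is a 1.2-fold lower number from compound 3 to compound 4 (0.08 log units; within the scatter), which is not beyond the scatter, and the range is set wide to reflect the missing comparison. Compound 4 is therefore estimated at 10 nM, with a range from 2.5 nM to 40 nM.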

Compound 4, inhibition constant: 16 nM
Compound 4: middle estimate off by 1.6-fold (0.20 log units), on the low side; low and high end bracket the measured number.
By their numbers in this assay, from the lowest: compounds 3 and 4 (each within the scatter of the next); then compounds 1 and 2 (each within the scatter of the next).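

In this assay, within the data shown here, the first measured change at this carbonyl carbon, trifluoromethyl in place of methoxy, gives a 1.3-fold higher number from compound 3 to compound 4 (0.12 log units; within the scatter), so the exchange of methoxycarbonyl for (trifluoromethyl)carbonyl leaves the read-out within the scatter. The earlier compounds shown here showed only that the read-out can differ beyond the scatter among compounds carrying different aromatic substituents; this pair shows that, with the carbonyl kept in place, the group on it can change from methoxy to trifluoromethyl, despite their different heavy-atom and hydrogen-bond acceptor counts, without a step beyond the scatter. No measurement in hand accounts for this result.

Other groups on this carbonyl carbon remain open: a hydroxyl, giving a carboxylic acid, or an amine, giving an amide, would test whether the read-out stays within the scatter beyond methoxy and trifluoromethyl. Also open is whether the same exchange would leave the read-out within the scatter on compound 1, which gives 60 nM with its methoxycarbonyl group in this assay and has no (trifluoromethyl)carbonyl partner among the compounds shown.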